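Swapping the Aryl Group on a Weakly Active Triazole

This account rests on a few compounds, and the source may have more. Where it says the series, first, only, none or still open, it means among the compounds named here.

Compound 3, `COc1ccc(-n2cc(CSC(=S)N3CCN(C(=O)OC(C)(C)C)CC3)nn2)cc1`, was tested in a functional assay on ECa-109 cells (Homo sapiens) for inhibition, read by MTT assay, with a stated time of 72 h; a higher number here means a weaker inhibitor, a lower number a stronger inhibitor. In this assay compound 3 gives > 128000 nM, which is a limit of the assay rather than a number. Its close relative compound 1, `Cc1ccc(-n2cc(CSC(=S)N3CCN(C(=O)OC(C)(C)C)CC3)nn2)cc1`, gives 114000 nM. Among the measured compounds shown here, the only measured step at this position, an at least 1.1-fold higher number from compound 1 to compound 3 (0.05 log units; that floor lies within the scatter), shows the change methoxy in place of methyl on an aromatic carbon, and its floor lies within the scatter. Compound 2, `S=C(SCc1cn(Cc2ccccc2Cl)nn1)N1CCNCC1`, carries the same 2-chlorobenzyl group that enters here, but lacks the carbamate; in this assay compound 2 gives > 128000 nM, again a limit.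

Compound 4, `CC(C)(C)OC(=O)N1CCN(C(=S)SCc2cn(Cc3ccccc3Cl)nn2)CC1`, differs from compound 3 as follows: 2-chlorobenzyl in place of 4-methoxyphenyl on an aromatic nitrogen. For the measured compounds named here, the one measured step at this position was small, and every value so far sits at or near the assay limit (the limit of > 128000 nM in this assay, at which 2 of the 3 values shown sit), so no shift beyond the scatter is expected; the step of a number no higher from compound 3 to compound 4 (the limit leaves the size open) is estimated to stay flat. Compound 4 is therefore expected to give about 128000 nM, within a range from 60000 nM to 300000 nM.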

Compound 4, half-maximal inhibitory concentration: 11900 nM
Estimate against measurement, compound 4: 11-fold (1.03 log units) above; measured number below the stated range.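

In this assay the change to 2-chlorobenzyl on the aromatic nitrogen gives an at least 10-fold lower number from compound 3 to compound 4 (1.03 log units; beyond the scatter) and also a 9.6-fold lower number from compound 1 to compound 4 (0.98 log units; beyond the scatter) and this shows that the position can move the result beyond the scatter, which the swap of methoxy for methyl could not show. With 2-chlorobenzyl held in place, tert-butoxycarbonyl in place of hydrogen on the ring amine nitrogen also counts, giving an at least 10-fold lower number from compound 2 to compound 4 (1.03 log units; beyond the scatter) as its step. The steps from compound 2 and compound 3 give only a minimum size, because each starts from a limit: the limit of > 128000 nM in this assay, at which 2 of the 4 values shown sit.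

Still open, on these data alone, is whether the gain belongs to the chlorine or to the benzyl group that carries it, a question that a plain benzyl group on the same nitrogen would address. Also open, as far as these compounds go, is whether an acetyl group could stand in for tert-butoxycarbonyl.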